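Benzimidazolone ureas: swapping the amine-bearing side chain

This account rests on a few compounds, and the source may have more. Where it says the series, first, only, none or still open, it means among the compounds named here.

Of the compounds shown here, two of a shared core have been measured in an assay on HEK293 cells for displacement of a labelled ligand from 5-hydroxytryptamine receptor 4 (Homo sapiens), read by scintillation counting; a higher number here means a weaker inhibitor, a lower number a stronger inhibitor. Compound 1 `CC(C)n1c(=O)n(C(=O)NCC2CCNCC2)c2ccccc21` gives 39.8 nM. Within the data shown here, compound 2 `CC(C)n1c(=O)n(C(=O)NC2CCNCC2)c2ccccc21` gives 1580 nM, the highest of the two numbers; the only neighbouring step is a 40-fold higher number from compound 1 to compound 2 (1.60 log units; beyond the scatter), so removing the single carbon link between the amide-type nitrogen and the ring cost a great deal of binding. Compound 3 `CC(C)n1c(=O)n(C(=O)NCCN2CCNCC2)c2ccccc21` is not yet measured. It differs from compound 2 by 2-(piperazin-1-yl)ethyl in place of piperidin-4-yl on an amide-type nitrogen. This change reinstates a chain between the amide-type nitrogen and the ring, now two carbons long, while the ring itself gains a second nitrogen. Among the measured compounds shown here, only the step from compound 1 to compound 2 bears on this, and it shows that a spacer matters strongly, though the new chain and ring are not the same as in compound 1. Compound 3 is therefore expected to recover part of that loss, with a 5.3-fold lower number from compound 2 to compound 3 (0.72 log units; beyond the scatter), giving an estimated 300 nM within a range of 60 nM to 2000 nM.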

Compound 3, inhibition constant: 126 nM
The estimate for compound 3 lay 2.4-fold (0.38 log units) above the measured number; the range from low to high includes it.
By their numbers in this assay, from the lowest: compound 1; then compound 3; then compound 2.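

In this assay, the side chain on the amide-type nitrogen does not have to be the (piperidin-4-yl)methyl group of compound 1 for much of the lost binding to return: 2-(piperazin-1-yl)ethyl in place of piperidin-4-yl gives a 13-fold lower number from compound 2 to compound 3 (1.10 log units; beyond the scatter). Even so, compound 1 keeps a lead, with a 3.2-fold higher number from compound 1 to compound 3 (0.50 log units; beyond the scatter), so this new side chain recovers much of the loss but not all of it. No measurement available here gives a cause for either step.

Compound 3 differs from compound 2 in both its chain and its ring, so the share of each in the gain remains unresolved. On these data alone, a 2-(piperidin-4-yl)ethyl group would pair this chain with the earlier ring, and how it or a longer chain such as 3-(piperazin-1-yl)propyl would compare remains open.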